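This account rests on a few compounds, and the source may have more. Where it says the series, first, only, none or still open, it means among the compounds named here.

Compound 1 `COc1ccc(-c2cnc(NC(=O)c3ccc(O)cc3)n2C)cc1` was tested in a toxicity assay on THP-1 cells (Homo sapiens) for inhibition; a lower number here means that less compound is tolerated, a higher number that more compound is tolerated. In this assay compound 1 gives > 100000 nM, which is a limit of the assay rather than a number. Compound 2 `CCn1c(-c2ccc(OC)cc2)cnc1NC(=O)c1ccc(F)cc1` also gives > 100000 nM in this assay, again only a limit. Both compounds sit at the limit of > 100000 nM in this assay, at which 2 of the 2 values shown sit, so compound 1 stands where this assay stops reporting numbers. Compound 3 `COc1ccc(-c2cnc(NC(=O)C3CCCCC3)n2C)cc1` has not yet been measured in this assay and differs from compound 1 by cyclohexyl in place of 4-hydroxyphenyl on a carbonyl carbon. Going by the values given here, no step between measured compounds exists here, so the expected step of a number no higher from compound 1 to compound 3 (the limit leaves the size open) is none beyond the scatter. Compound 3 is therefore expected to give 100000 nM, with a range from 30000 nM to 300000 nM.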

Compound 3, half-maximal cytotoxic concentration: > 100000 nM
Compound 3: no number, only a limit (the forecaster's own chance of this, stated with the estimate: 70%); the middle value lies on the limit itself.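

No step can be read from compound 1 to compound 3 in this assay, because both results are limits: the limit of > 100000 nM in this assay, at which 3 of the 3 values shown sit.

The compounds shown leave open whether cyclohexyl in place of 4-hydroxyphenyl on a carbonyl carbon changes the half-maximal cytotoxic concentration at all.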